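Compound 1 to compound 4: carbamoyl replaced by trifluoromethoxy

This account rests on a few compounds, and the source may have more. Where it says the series, first, only, none or still open, it means among the compounds named here.

Compound 1 (`Cc1cc(NC(=O)Nc2cccc(C(N)=O)c2)c2ccccc2n1`) reads > 25000 nM in an ADME assay on HepG2 cells (Homo sapiens) for cytotoxicity, with a stated time of 72 h (on this read-out lower numbers stand for an effect already at smaller amounts and higher numbers for an effect only at larger amounts of compound), and this is a limit of the assay, not a number. Compound 1 thus stands at the limit of > 25000 nM in this assay, at which 2 of the 3 values shown sit, which gives no exact starting point. Compound 3 (`Cc1cc(NC(=O)Nc2ccc([N+](=O)[O-])c(C(F)(F)F)c2)c2ccccc2n1`) likewise reads > 25000 nM in this assay, again a limit. For the measured compounds named here, compound 2 (`COC(=O)c1ccc(NC(=O)Nc2cc(C)nc3ccccc23)cc1`) gives 20000 nM in this assay, the only true number in the set.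

Compound 4 (`Cc1cc(NC(=O)Nc2cccc(OC(F)(F)F)c2)c2ccccc2n1`) carries trifluoromethoxy in place of carbamoyl on an aromatic carbon, meta to a large group (trifluoromethoxy in place of carbamoyl on an aromatic carbon). Going by the values given here, no measured step is available to size this change, so the expectation rests on compound 2 at 20000 nM as the single numeric reading. The estimated at least 1.3-fold lower number from compound 1 to compound 4 (0.14 log units; that floor lies within the scatter) in this assay is expected to stay within the usual scatter, if anything towards lower numbers. For compound 4 the estimate is 18000 nM in this assay, with an expected range from 8000 nM to 30000 nM as the likely span of a measurement.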

Compound 4, half-maximal effective concentration: 13000 nM
The estimate for compound 4 lay 1.4-fold (0.14 log units) above the measured number; the measured number falls inside the stated range.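

For the compounds shown here, the exchange of carbamoyl for trifluoromethoxy on this aromatic carbon, meta to a large group, gives an at least 1.9-fold lower number from compound 1 to compound 4 (0.28 log units; that floor lies within the scatter) in this assay as the first step at this position that can be sized. With this change the reading at the position goes from a limit of the assay to a true number, yet the printed floor alone shows no shift beyond the scatter. The step remains a floor and not a full size because compound 1 sits at a limit of the assay: the limit of > 25000 nM in this assay, at which 2 of the 4 values shown sit.

On these data alone, the true distance between compound 1 and compound 4 remains open, so the step may be larger than its floor. Also open, as far as these compounds go, is how an amine, a carboxylic acid or a longer chain would read in this assay on the same aromatic carbon.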